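A few compounds are considered here, and "the series" means these few. Any claim that something is new, unique, unknown or untested is made for them only; others in the source may bear on it.

Working notes on the series. In a functional assay on P388 cells (Mus musculus) for cytotoxicity, read by MTT assay, with a stated time of 72 h (a higher number here means a weaker inhibitor, a lower number a stronger inhibitor), compound 1 `OCC#CCSc1cnc2ccccc2c1[Se]CC#CCBr` gives 1.6 ug/mL. Compound 2 `COc1c(SCC#CCO)cnc2ccccc12` gives 23.2 ug/mL in this assay. Compound 3 `C#CCSc1cnc2ccccc2c1[Se]CC#CCBr` gives 1.2 ug/mL in this assay. Compound 3 thus holds the lowest number of the three, though the step of a 1.3-fold lower number from compound 1 to compound 3 (0.12 log units; within the scatter) leaves it indistinguishable from compound 1, while compound 2 sits far higher.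

Compound 4 `C#CCSc1cnc2ccccc2c1SCC#CCO` differs from compound 3 as follows: a group of 6 heavy atoms (4 carbon, 1 oxygen, 1 sulfur; no ring) in place of a group of 6 heavy atoms (4 carbon, 1 selenium, 1 bromine; no ring), on an aromatic carbon. Within the data shown here, the one measured step bearing on this position is a 15-fold higher number from compound 1 to compound 2 (1.16 log units; beyond the scatter), where the same selenium- and bromine-bearing group left and a much smaller group entered. Here the entering group keeps a triple bond outside aromatic rings and brings a hydrogen-bond donor, so a rise in this assay is expected, probably smaller than that step. Compound 4 is expected near 7 ug/mL, within 2.5 ug/mL to 20 ug/mL. This amounts to an expected step of a 5.8-fold higher number from compound 3 to compound 4 (0.77 log units; beyond the scatter).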

Compound 4, concentration for 50% inhibition: 4 ug/mL
Estimate against measurement, compound 4: 1.8-fold (0.24 log units) above; the range from low to high includes it.
By their numbers in this assay, from the lowest: compounds 3 and 1 (each within the scatter of the next); then compound 4; then compound 2.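

With the heavy-atom count unchanged and a triple bond outside aromatic rings retained on both sides, this position still responds in this assay: a 3.3-fold higher number from compound 3 to compound 4 (0.52 log units; beyond the scatter). This step is modest, whereas a 15-fold higher number from compound 1 to compound 2 (1.16 log units; beyond the scatter) is large, so replacing the selenium- and bromine-bearing group need not bring the full rise seen with the much smaller group. No available evidence accounts for the rise.

On these data alone, the exchange alters several atoms at once, so the part played by each remains open. A sulfur-linked chain ending in bromine, or a selenium-linked chain ending in hydroxyl, could separate them.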